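The source may hold more compounds than are shown below. What is called first, only, known or untested is meant among the compounds shown, and "the series" means these compounds.

The compounds measured so far in a functional assay on HeLa cells (Homo sapiens) for inhibition, read by CCK-8 assay, with a stated time of 48 h (a higher number here means a weaker inhibitor, a lower number a stronger inhibitor), are:

Compound 1, `Cc1ccc(C2=NN(C3=NC(=O)CS3)C(c3ccc4ccccc4c3)C2)cc1`: 1760 nM
Compound 2, `O=C1CSC(N2N=C(c3ccc(Br)cc3)CC2c2cccc3ccccc23)=N1`: 5810 nM
Compound 3, `Clc1ccc(C2=NN(C3=NC(c4ccccc4)CS3)C(c3ccc4ccccc4c3)C2)cc1`: 7560 nM

Among these three numbers compound 2 stands second highest. Its nearest neighbour is compound 3, whose number lies within the usual scatter of compound 2, so nothing separates the two. Among the measured compounds shown here, compound 1 is furthest away, with a number low enough to fall beyond the scatter of compound 2; compound 1 differs from compound 2 in more than one place, so the two values alone show only that compound 1 inhibits more strongly.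

The compound not yet measured is compound 4, `COc1ccc(C2=NN(C3=NC(=O)CS3)C(c3cccc4ccccc34)C2)cc1`. Set against compound 2, the change is methoxy in place of bromo on an aromatic carbon. For the measured compounds named here, no pair of measured compounds differs in one place, so there is no measured step to lean on for this change. With nothing in the three measured compounds pointing clearly one way, the step from compound 2 to compound 4 in this assay is expected to be small, a 1.3-fold lower number from compound 2 to compound 4 (0.11 log units; within the scatter), and not beyond the scatter with any confidence. Compound 4 is therefore estimated at 4500 nM in this assay, with a range from 1500 nM to 12000 nM.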

Compound 4, half-maximal inhibitory concentration: 2540 nM
The estimate for compound 4 lay 1.8-fold (0.25 log units) above the measured number, within the range that was stated.
By their numbers in this assay, from the lowest: compounds 1 and 4 (each within the scatter of the next); then compounds 2 and 3 (each within the scatter of the next).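

In this assay, the change from 4-bromophenyl to 4-methoxyphenyl gives a 2.3-fold lower number from compound 2 to compound 4 (0.36 log units; beyond the scatter) and is the first single-place step among these compounds. It shows that this position, on an aromatic carbon para to a large group, is not indifferent to what it carries, since the two numbers are separated by more than the usual scatter. The step is modest, and with methoxy the entering group counts two heavy atoms and one hydrogen-bond acceptor where bromo counted one heavy atom and no acceptor, but a single step cannot tell which of these differences goes with the lower number. Nothing available here bears on why the number falls with this change.

The compounds shown leave open whether a hydroxyl, an ethoxy or a dimethylamino group at this position would move the number further in the same direction or back towards that of compound 2. They also leave open whether the same exchange of bromo for methoxy would give a step of similar size on the core of compound 1 or on the core of compound 3.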